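A few compounds are considered here, and "the series" means these few. Any claim that something is new, unique, unknown or untested is made for them only; others in the source may bear on it.

Three related compounds share one core and differ only in the group carried at the far end of the molecule. Compound 1 `O=C(/C=C/c1ccc2c(c1)B(O)OC2)c1ccc(-c2ccccc2)cc1` bears a phenyl there, compound 2 `O=C(/C=C/c1ccc2c(c1)B(O)OC2)c1ccc(OCc2ccccc2)cc1` a benzyloxy, and compound 3 `O=C(/C=C/c1ccc2c(c1)B(O)OC2)c1ccc(O)cc1` a hydroxy. In a toxicity assay on WI-38 cells (Homo sapiens) for cytotoxicity, read by MTT assay, with a stated time of 48 h (on this read-out higher numbers stand for weaker inhibition and lower numbers for stronger inhibition), compound 1 gives 18300 nM. In this assay compound 2 gives > 100000 nM, which is a limit of the assay rather than a number. For the measured compounds named here, the one measured step is therefore an at least 5.4-fold higher number from compound 1 to compound 2 (0.73 log units; beyond the scatter), and how far it really goes is hidden by the limit of > 100000 nM in this assay, at which 1 of the 2 values shown sits. On the numbers shown, compound 2 thus stands at the weak end of the pair, with only a limit to its name.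

The change from compound 2 to compound 3 is hydrogen in place of benzyl on an oxygen on an aromatic ring. Going by the values given here, no measured step exchanges a benzyl for hydrogen on such an oxygen, so the only guide is that the benzyloxy-bearing compound 2 already sits at the limit. From that starting point the step of a number no higher from compound 2 to compound 3 (the limit leaves the size open) is expected to be small and within the scatter, with a fair chance of another limit. Compound 3 is estimated at 100000 nM, between 30000 nM and 300000 nM.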

Compound 3, half-maximal inhibitory concentration: > 100000 nM
Compound 3 gave a limit, no number; the forecaster's own chance of this, stated with the estimate: 60%; the middle value sits exactly at the limit.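

Compound 3 shows that the limit seen with compound 2 does not depend on the benzyl: with hydrogen in place of benzyl on the oxygen on the aromatic ring, the result in this assay is again a limit and not a number. The phenyl of compound 1 can therefore give way to two different groups, benzyloxy and hydroxy, and the second replacement gives an at least 5.4-fold higher number from compound 1 to compound 3 (0.73 log units; beyond the scatter). Among these three compounds, only the one with phenyl gives a measurable number, while the step for removing the benzyl cannot be read, because both compounds sit at the same limit: the limit of > 100000 nM in this assay, at which 2 of the 3 values shown sit.

For the compounds shown here, how far compound 2 and compound 3 lie beyond that limit, and whether they differ from each other at all, stays unknown, and the comparison at this position rests on the single number of compound 1. Also open, from the compounds shown here alone, is where an amine, a carboxylic acid or a methoxy at the same place would fall in this assay, and whether any of them would give a number near that of compound 1 or another limit.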